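From compound 2 to compound 3: a side-chain exchange

The compounds below may be only part of what the source reports. "The series", "measured", "known", "first", "only" and "open" are said of these compounds alone.

In a functional assay on PC-3 cells (Homo sapiens) for inhibition, with a stated time of 48 h, tested at 50 uM (on this read-out higher numbers stand for more inhibition of growth at the one concentration tested and lower numbers for less inhibition of growth), compound 1 (`C=C[C@@](C)(/C=C/c1ccc(OC(=O)CCCC)cc1)CCC=C(C)C`) gives 42% and compound 2 (`C=C[C@@](C)(/C=C/c1ccc(O)cc1)CC/C=C(/C)C=O`) gives 51%. These two numbers lie within the scatter of each other, so neither compound ranks ahead. Compound 3 (`C=C[C@@](C)(/C=C/c1ccc(O)cc1)CCC1OC1(C)C`) differs from compound 2 by 3,3-dimethyloxiran-2-yl in place of 2-formylprop-1-en-1-yl on a saturated chain carbon, three bonds along the chain from two double-bonded chain carbons: 3,3-dimethyloxiran-2-yl in place of 2-formylprop-1-en-1-yl. Among the compounds with values here, no measured step shows what this exchange does, so no shift beyond the scatter is expected in this assay. The expected change is small, a number 6 percentage points lower from compound 2 to compound 3 (within the scatter). Compound 3 is estimated at 45%, within a range of 28% to 62%.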

Compound 3, percent growth inhibition at one concentration: 46%
Compound 3: the middle estimate sits 1 percentage points below what was measured; low and high end bracket the measured number.
By their numbers in this assay, from the lowest: compounds 1, 3 and 2 (each within the scatter of the next).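

Within the data shown here, the first step at this position reads a number 5 percentage points lower from compound 2 to compound 3 (within the scatter) in this assay. On this read-out, then, a three-membered ring with one hetero atom can stand in for the open chain with its two double bonds, with no difference beyond the scatter at the one concentration tested. Nothing shown gives a reason for this result.

Among these compounds, only this one exchange has been read here, so it remains open whether the position would respond to a group of another kind, such as a carboxylic acid or an amine. Compound 1 differs from compound 2 and compound 3 in more than one place and adds nothing to this question.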